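Five-membered ring replacements at the chlorinated benzyl position

The compounds below may be only part of what the source reports. "The series", "measured", "known", "first", "only" and "open" are said of these compounds alone.

Compound 3 `Cc1ccc(-c2ccc(CN3CCC(O)(Cn4cnc5c(-c6ccc(CN)cc6)n(C)nc5c4=O)CC3)c(Cl)c2)s1` gives the lowest number of the three measured, 101 nM in an assay on isolated protein for inhibition of ubiquitin carboxyl-terminal hydrolase 7 (Homo sapiens), with stated times of 30 min and 2 h; a higher number here means a weaker inhibitor, a lower number a stronger inhibitor. Compound 2 `Cn1nc2c(=O)n(CC3(O)CCN(Cc4ccc(-c5ccsc5Cl)cc4Cl)CC3)cnc2c1-c1ccc(CN)cc1` gives 453 nM, and compound 1 `Cn1nc2c(=O)n(CC3(O)CCN(Cc4ccc(C5CCCO5)cc4Cl)CC3)cnc2c1-c1ccc(CN)cc1` gives 3820 nM. The steps ending at compound 3 were a 38-fold lower number from compound 1 to compound 3 (1.58 log units; beyond the scatter) and a 4.5-fold lower number from compound 2 to compound 3 (0.65 log units; beyond the scatter); the remaining step was an 8.4-fold lower number from compound 1 to compound 2 (0.93 log units; beyond the scatter). Compound 4 `Cn1nc2c(=O)n(CC3(O)CCN(Cc4ccc(-c5cncs5)cc4Cl)CC3)cnc2c1-c1ccc(CN)cc1` carries 1,3-thiazol-5-yl in place of 5-methylthiophen-2-yl on an aromatic carbon. The two steps involving compound 3 bear on this change; the swap from one five-membered aromatic ring to another was modest, the swap from oxolane large. A modest step toward a higher number is therefore expected, a 2.5-fold higher number from compound 3 to compound 4 (0.39 log units; beyond the scatter). Compound 4 is estimated at 250 nM, with a range from 80 nM to 800 nM.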

Compound 4, half-maximal inhibitory concentration: 117 nM
Compound 4: middle estimate off by 2.1-fold (0.33 log units), on the high side; low and high end bracket the measured number.
By their numbers in this assay, from the lowest: compounds 3 and 4 (each within the scatter of the next); then compound 2; then compound 1.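

In this assay the swap to 1,3-thiazol-5-yl gives a 1.2-fold higher number from compound 3 to compound 4 (0.06 log units; within the scatter) and so shows that this position accepts a five-membered aromatic ring with 2 hetero atoms and no methyl group. The steps of a 3.9-fold lower number from compound 2 to compound 4 (0.59 log units; beyond the scatter) and a 33-fold lower number from compound 1 to compound 4 (1.51 log units; beyond the scatter) show that the 2-chlorothiophen-3-yl and oxolan-2-yl compounds both stay apart from this ring as well. No measurement on hand explains these steps.
Still open, going by these compounds, is how a pyridine ring would fare at this place. So is the effect of an aminomethyl group or a carboxylic acid on the thiazole ring.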